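Anilino-Pyrimidinyl Ureas on PC-9 Cells: Predicting Compound 4

The source may report more compounds than this note shows. Statements on the series, on what has been measured and on what is new or still open speak of the compounds shown alone.

Measured compounds:
compound 1, `COc1cc(Br)ccc1Nc1cc(NC(=O)Nc2c(Cl)cccc2Cl)ncn1`, 90.5%
compound 2, `COc1ccc(Nc2cc(NC(=O)Nc3c(Cl)cccc3Cl)ncn2)cc1C`, 80.1%
compound 3, `O=C(Nc1cc(Nc2ccc(F)c(Cl)c2)ncn1)Nc1c(Cl)cccc1Cl`, 91.1%

In a functional assay on PC-9 cells (Homo sapiens) for inhibition, read by MTT assay, with a stated time of 48 h, tested at 10 uM (on this read-out higher numbers stand for more inhibition at the one concentration tested (going by the name of the read-out) and lower numbers for less inhibition), compound 3 stands highest of the three numbers, though compound 1 lies within the scatter of it, as a number 0.6 percentage points higher from compound 1 to compound 3 (within the scatter) shows; only compound 2 sits clearly lower, by a number 11 percentage points higher from compound 2 to compound 3 (beyond the scatter). Compound 4, `CCc1ccc(Nc2cc(NC(=O)Nc3c(Cl)cccc3Cl)ncn2)cc1`, differs from compound 3 in one place: 4-ethylphenyl in place of 3-chloro-4-fluorophenyl on a nitrogen on an aromatic ring. For the measured compounds named here, two steps bear on this. The halogen-to-halogen swap a number 0.6 percentage points higher from compound 1 to compound 3 (within the scatter) stayed within the scatter, whereas replacing an alkyl- and methoxy-bearing ring gave a number 11 percentage points higher from compound 2 to compound 3 (beyond the scatter). Since compound 4 carries an alkyl-only ring, a modest loss is expected, a number 8.1 percentage points lower from compound 3 to compound 4 (within the scatter), and compound 4 is estimated at 83%, between 68% and 93%.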

Compound 4, a percentage reported as inhibition, at one concentration (the size of the read-out at that concentration, not a potency): 70.1%
Beside the measured number, compound 4's estimate is 12.9 percentage points above it; the range from low to high includes it.
By their numbers in this assay, from the lowest: compounds 4 and 2 (each within the scatter of the next); then compounds 1 and 3 (each within the scatter of the next).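

In this assay, 4-ethylphenyl on the nitrogen gives up inhibition relative to both halogen-bearing rings, with a number 21 percentage points lower from compound 3 to compound 4 (beyond the scatter) and a number 20.4 percentage points lower from compound 1 to compound 4 (beyond the scatter). Against the halogen-free 4-methoxy-3-methylphenyl ring, the change gives a number 10 percentage points lower from compound 2 to compound 4 (within the scatter), so among these four compounds, the two without halogen on this ring fall apart from the two with it, and none goes against this. Nothing available here explains that split.

Going by these compounds, whether the halogen itself matters stays open, as these rings differ by more than a halogen. Also open, on these data alone, is how a propyl chain, an amine or a carboxylic acid in place of ethyl would read out.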